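The source may report more compounds than this note shows. Statements on the series, on what has been measured and on what is new or still open speak of the compounds shown alone.

Measured compounds:
Compound 1 `CC[C@@H](Nc1c(C#N)c(-c2ccc(-c3cnccc3C)cc2)nc2cnccc12)C(N)=O` gives 2 in a physicochemical assay for lipophilicity, read by HPLC, at pH 7.5; on this read-out higher numbers stand for higher lipophilicity and lower numbers for lower lipophilicity.
Compound 2 `CC[C@@H](Nc1c(C#N)c(-c2ccc(-c3ccccc3COC)cc2)nc2cnccc12)C(N)=O` gives 2.6 in this assay.
Compound 3 `CC[C@@H](Nc1c(C#N)c(-c2ccc(-c3cccnc3C)cc2)nc2cnccc12)C(N)=O` gives 1.9 in this assay.

Compound 3 stands at the low end of the three numbers. Its nearest neighbour is compound 1, with a number 0.10 log units lower from compound 1 to compound 3 (within the scatter), a gap that does not rise above the scatter. Compound 2 lies furthest from it, with a number 0.70 log units lower from compound 2 to compound 3 (beyond the scatter). Compound 4 `CC[C@@H](Nc1c(C#N)c(-c2ccc(-c3cccc(OC)c3)cc2)nc2cnccc12)C(N)=O` has not yet been measured in this assay. It differs from compound 3 in one place: 3-methoxyphenyl in place of 2-methylpyridin-3-yl on an aromatic carbon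

Within the data shown here, two measured steps bear on this change. Going from a pyridine-bearing group to a group whose ring is carbon only, the step of a number 0.60 log units higher from compound 1 to compound 2 (beyond the scatter) was modest and upward; in the other direction, a number 0.70 log units lower from compound 2 to compound 3 (beyond the scatter) was modest and downward. Both steps exchange a six-membered aromatic ring with one nitrogen for a ring of carbon only, as the step from compound 3 to compound 4 does. Compound 4 is therefore expected to sit higher than compound 3 by a modest step, a number 0.70 log units higher from compound 3 to compound 4 (beyond the scatter), beyond the scatter. The value of compound 4 in this assay is estimated at 2.6, with a range from 2.2 to 3.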

Compound 4, distribution coefficient: 2.7
The estimate for compound 4 lay 0.10 log units below the measured number; the measured number falls inside the stated range.
By their numbers in this assay, from the lowest: compounds 3 and 1 (each within the scatter of the next); then compounds 2 and 4 (each within the scatter of the next).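

In this assay, 3-methoxyphenyl in place of 2-methylpyridin-3-yl gives a number 0.80 log units higher from compound 3 to compound 4 (beyond the scatter), and in place of 4-methylpyridin-3-yl it gives a number 0.70 log units higher from compound 1 to compound 4 (beyond the scatter), although the leaving and entering groups carry the same counts of hydrogen-bond donors and acceptors and no net charge. Replacing 2-(methoxymethyl)phenyl with 3-methoxyphenyl gives a number 0.10 log units higher from compound 2 to compound 4 (within the scatter), so these two groups on a ring of carbon only cannot be told apart by this read-out. Across the four compounds, the two with a ring of carbon only at this position both stand beyond the scatter from the two with a pyridine ring, no compound shown goes against this split, and no measurement at hand gives a reason for it.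

On these data alone, each step changes the ring and its substituent together, so what the ring nitrogen contributes on its own remains open, and a methoxypyridinyl or a methylphenyl group would be needed to separate the two. Also open is how the number would respond to a carboxylic acid, an amine or a longer ether chain on this ring, since every substituent shown is a methyl group or a short methoxy-bearing group.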